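Chloro to methyl on the aryl group, second core

The compounds below may be only part of what the source reports. "The series", "measured", "known", "first", "only" and "open" are said of these compounds alone.

Compounds measured so far:
compound 1 `Cc1ccc(-c2cs/c(=N/NC(=O)CSc3nnnn3-c3ccccc3)n2-c2ccccc2)cc1` — > 500 ug/mL (a limit)
compound 2 `O=C(CSc1nnnn1-c1ccccc1)N/N=c1/scc(-c2ccc(Cl)cc2)n1-c1ccccc1` — 313 ug/mL
compound 3 `O=C(CSc1ncccn1)N/N=c1/scc(-c2ccc(Cl)cc2)n1-c1ccccc1` — 397 ug/mL

In an ADME assay on NIH3T3 cells (Mus musculus) for cytotoxicity, read by MTT assay, with a stated time of 24 h (a higher number here means a weaker inhibitor, a lower number a stronger inhibitor), compound 2 gives 313 ug/mL and compound 3 gives 397 ug/mL. Compound 1 reaches only a limit of the assay, > 500 ug/mL. The two cores differ by pyrimidin-2-yl in place of 1-phenyl-1H-tetrazol-5-yl on a sulfur, a step of a 1.3-fold higher number from compound 2 to compound 3 (0.10 log units; within the scatter). The change now carried from compound 3 to compound 4 `Cc1ccc(-c2cs/c(=N/NC(=O)CSc3ncccn3)n2-c2ccccc2)cc1` is methyl in place of chloro on an aromatic carbon; the same change methyl in place of chloro on an aromatic carbon gave an at least 1.5-fold higher number from compound 2 to compound 1 (0.20 log units; that floor lies within the scatter), where the floor rests on (the limit of > 500 ug/mL in this assay, at which 1 of the 3 values shown sits). Because compound 1 sits at the limit of > 500 ug/mL in this assay, at which 1 of the 3 values shown sits, a like shift from compound 3 is expected to run into the same limit. The expected step is a 1.4-fold higher number from compound 3 to compound 4 (0.15 log units; within the scatter). Compound 4 is therefore estimated at 560 ug/mL, between 350 ug/mL and 900 ug/mL, most likely reported only as a limit.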

Compound 4, half-maximal inhibitory concentration: > 500 ug/mL
Compound 4 was reported as a limit; the forecaster's own chance of this, stated with the estimate: 65%; the middle value does not contradict the limit.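

In this assay, methyl in place of chloro on an aromatic carbon gives an at least 1.2-fold higher number from compound 3 to compound 4 (0.10 log units; that floor lies within the scatter), a floor resting on a limit rather than a measured size. Both cores are thus compatible with one shared shift, but this does not show that the change carries over from one core to the other with the same size: the same change on two cores in this assay, an at least 1.5-fold higher number (0.20 log units; that floor lies within the scatter) from compound 2 to compound 1 and an at least 1.2-fold higher number (0.10 log units; that floor lies within the scatter) from compound 3 to compound 4; the limit leaves it open whether they differ. The step joining compound 1 and compound 4 cannot be read, since both compounds are reported only as limits: the limit of > 500 ug/mL in this assay, at which 2 of the 4 values shown sit.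

The compounds shown leave open how an amine or a carboxylic acid in place of chloro on that aromatic carbon would read in this assay. They also leave open whether a value clear of the limit would give this change a readable size on either core.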